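The compounds below may be only part of what the source reports. "The series", "measured", "known", "first", "only" and "open" are said of these compounds alone.

Compound 1, `CCCCCc1cc2c(=O)n(CCC)cnc2s1`: > 100 ug/mL
Compound 2, `CCCCCCCc1cc2c(=O)n(CC#N)cnc2s1`: > 100 ug/mL

In an ADME assay on HCT-116 cells (Homo sapiens) for cytotoxicity, read by MTT assay, with a stated time of 11 days (on this read-out higher numbers stand for weaker inhibition of growth and lower numbers for stronger inhibition of growth), the value of compound 1 is a limit and not a number: compound 1 stands at the limit of > 100 ug/mL in this assay, at which 2 of the 2 values shown sit. The value of compound 2 is likewise a limit in this assay. Compound 3, `CCCCCc1cc2c(=O)n(CC3CC3)cnc2s1`, differs from compound 1 by cyclopropyl in place of ethyl on a saturated chain carbon bound to an aromatic nitrogen. Going by the values given here, no measured pair covers this change, and neither measured compound gives a number to move from. With both measured values at the limit, the step that the limit leaves unreadable from compound 1 to compound 3 is expected to be none beyond the scatter. Compound 3 is therefore estimated at 150 ug/mL, with a range from 50 ug/mL to 400 ug/mL.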

Compound 3, concentration for 50% growth inhibition: > 100 ug/mL
Compound 3 gave a limit, no number; the forecaster's own chance of this, stated with the estimate: 80%; the middle value is on the limit's open side.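

Going by these compounds alone, no step from compound 1 to compound 3 can be read, because each gives only a limit and no number in this assay: the limit of > 100 ug/mL in this assay, at which 3 of the 3 values shown sit.

The compounds shown leave open how strongly any of them inhibits growth, and whether cyclopropyl in place of ethyl changes that at all.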